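Amino in place of hydrogen on the core of compound 1

The source may report more compounds than this note shows. Statements on the series, on what has been measured and on what is new or still open speak of the compounds shown alone.

Measured compounds:
compound 1, `Cc1cccc(CNC(=O)n2cnc3ccccc32)c1` — 8.3 nM
compound 2, `O=C(NCCCCc1ccccc1)Nc1nc2ccccc2[nH]1` — > 10000 nM

In an assay on HEK293 cells for inhibition of acid ceramidase (Homo sapiens), read by fluorescence, with stated times of 30 min and 1 h (on this read-out lower numbers stand for stronger inhibition and higher numbers for weaker inhibition), compound 1 gives 8.3 nM, the only number among the two results shown. Compound 2 gives only a limit in this assay, > 10000 nM; this is the limit of > 10000 nM in this assay, at which 1 of the 2 values shown sits, and not a number. Going by the values given here, no two measured compounds differ in one place, so no single step is available as a guide.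

Compound 3, `Cc1cccc(CNC(=O)n2c(N)nc3ccccc32)c1`, is not yet measured in this assay. It differs from compound 1 by amino in place of hydrogen on an aromatic carbon. Only compound 1 offers a starting point for an expectation, and the results shown give no comparison in which this change stands alone. The expected step is a 4.8-fold higher number from compound 1 to compound 3 (0.68 log units; beyond the scatter), a moderate weakening that may still fall close to the scatter. For compound 3 the estimate in this assay is 40 nM, within a range from 8 nM to 300 nM.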

Compound 3, half-maximal inhibitory concentration in the acid ceramidase assay: 8.5 nM
For compound 3 the middle estimate is 4.7-fold (0.67 log units) above the measured one, and the stated range covers the measured number.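

In the acid ceramidase assay, amino in place of hydrogen on an aromatic carbon, between two ring nitrogen atoms, gives a 1.0-fold higher number from compound 1 to compound 3 (0.01 log units; within the scatter), so this position of the core of compound 1 accepts the amino group with no change that can be read on this read-out. The same change does register in a physicochemical assay for metabolic stability, read by HPLC, at pH 4.5, tested at 10 uM (a lower number here means that the compound disappears faster, a higher number that the compound lasts longer), where it gives an at least 4.4-fold lower number from compound 1 to compound 3 (0.64 log units; beyond the scatter). That step rests on a limit and not on a number, for in the physicochemical assay compound 1 gives > 2 h as a limit of this assay: the limit of > 2 h in the physicochemical assay, at which 1 of the 2 values shown sits.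

On these data alone, what stays open is whether a larger group at this position, such as a methylamino or an acetamido group, would hold the number in the acid ceramidase assay. As far as these compounds go, it is also open whether such a group would last longer in the physicochemical assay than compound 3, at 0.45 h.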